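Shortening the arm and losing iodine in a hexokinase probe

This account rests on a few compounds, and the source may have more. Where it says the series, first, only, none or still open, it means among the compounds named here.

Compound 3 `O=C(CI)NCCCC(=O)NCCCCCCNc1ncnc2c1ncn2[C@@H]1O[C@H](COP(=O)(O)OP(=O)(O)OP(=O)(O)O)[C@@H](O)[C@H]1O` gives 0% in an assay on isolated protein for inhibition of hexokinase-1 (Rattus norvegicus), with a stated time of 6 h, tested at 10 mM (a lower number here means less inhibition, a higher number more inhibition at the concentration tested (going by the name of the read-out)), level with compound 2 `O=C(CI)NCCCCC(=O)NCCCCCCNc1ncnc2c1ncn2[C@@H]1O[C@H](COP(=O)(O)OP(=O)(O)OP(=O)(O)O)[C@@H](O)[C@H]1O` at 0%, together the lowest of three numbers, while compound 1 `O=C(CI)NCCCCCCCCNc1ncnc2c1ncn2[C@@H]1O[C@H](COP(=O)(O)OP(=O)(O)OP(=O)(O)O)[C@@H](O)[C@H]1O` gives 35%. Compound 4 `CC(=O)NCCCCCCCCNc1ncnc2c1ncn2[C@@H]1O[C@H](COP(=O)(O)OP(=O)(O)OP(=O)(O)O)[C@@H](O)[C@H]1O` is not yet measured; it differs from compound 3 by a group of 6 heavy atoms (4 carbon, 1 nitrogen, 1 oxygen; no ring) in place of a group of 11 heavy atoms (6 carbon, 2 nitrogen, 2 oxygen, 1 iodine; no ring), on a saturated chain carbon, six bonds along the chain from a nitrogen on an aromatic ring. Going by the values given here, the steps that bear on it are a number 35 percentage points lower from compound 1 to compound 3 (beyond the scatter) and a number 35 percentage points lower from compound 1 to compound 2 (beyond the scatter), both large, showing that lengthening the arm of compound 1 removed all inhibition. Among the compounds with values here, compound 4 returns to the shorter arm but without the iodine, and no measured pair shows that change alone, so a step of a number 10 percentage points higher from compound 3 to compound 4 (within the scatter) is expected, modest and upward. Compound 4 is therefore estimated at 10%, within 0% to 30%.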

Compound 4, a percentage reported as inhibition, at one concentration (the size of the read-out at that concentration, not a potency): 0%
Beside the measured number, compound 4's estimate is 10 percentage points above it, within the range that was stated.
By their numbers in this assay, from the lowest: compounds 2, 3 and 4 (each within the scatter of the next); then compound 1.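

In this assay, putting hydrogen in place of iodo on the saturated chain carbon bound to a carbonyl carbon, with the rest of the molecule unchanged, gives a number 35 percentage points lower from compound 1 to compound 4 (beyond the scatter), so on this arm the inhibition seen depends on the iodine being there. The other two comparisons read no change at the digits printed from compound 3 to compound 4 (within the scatter) and no change at the digits printed from compound 2 to compound 4 (within the scatter), which places the iodine-free compound level with two iodine-bearing compounds whose arms differ. No measurement here explains why. From the compounds shown here alone, whether bromo or chloro in place of iodo would keep any inhibition remains open, as does the effect of a shorter or longer plain carbon chain carrying the iodine.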